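A few compounds are considered here, and "the series" means these few. Any claim that something is new, unique, unknown or untested is made for them only; others in the source may bear on it.

Measured compounds:

Compound 1, `O=c1c(OC/C(=N/O)c2ccccc2)c(-c2ccccc2)oc2ccccc12`: 7210000 nM
Compound 2, `O=c1c(OC/C(=N/O)c2ccc(F)cc2)c(-c2ccccc2)oc2ccccc12`: 6900000 nM
Compound 3, `O=c1cc(-c2ccccc2)oc2cc(OC/C(=N/O)c3ccccc3)ccc12`: 2000000 nM

The three measured compounds were tested in a functional assay on SK-HEP1 cells (Homo sapiens) for antiproliferative activity; on this read-out lower numbers stand for stronger inhibition of growth and higher numbers for weaker inhibition of growth. Compound 1 and compound 2 share one core and compound 3 carries another; compound 3 has the same atoms as compound 1 joined differently, and the difference between the two cores is not broken down here. In this assay compound 3 gives the lowest number of the three.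

Compound 2 differs from compound 1 by one change, (fluoro in place of hydrogen on an aromatic carbon), and the step it made was a 1.0-fold lower number from compound 1 to compound 2 (0.02 log units; within the scatter).

Compound 4, `O=c1cc(-c2ccccc2)oc2cc(OC/C(=N/O)c3ccc(F)cc3)ccc12`, has not yet been measured. Among the compounds with values here, it differs from compound 3 by fluoro in place of hydrogen on an aromatic carbon, the same change as the one from compound 1 to compound 2, made on the same place of the ring.

What is expected for compound 4 rests on one earlier step only. Because that step was a 1.0-fold lower number from compound 1 to compound 2 (0.02 log units; within the scatter), the same change on the core of compound 3 is expected to move the number about as little, so the estimated step from compound 3 to compound 4 is a 1.1-fold lower number from compound 3 to compound 4 (0.02 log units; within the scatter). On that basis compound 4 is estimated to give 1900000 nM in this assay, with the expectation lying between 800000 nM and 4500000 nM. A single earlier step is a thin base, so the range is kept wide.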

Compound 4, concentration for 50% growth inhibition: 2300000 nM
Compound 4: middle estimate off by 1.2-fold (0.08 log units), on the low side, and the stated range covers the measured number.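

In this assay, the change from phenyl to 4-fluorophenyl on the core of compound 3 gave a 1.2-fold higher number from compound 3 to compound 4 (0.06 log units; within the scatter) and so left no readable mark on the number, and the same change had left none on the core of compound 1. Set side by side, the two steps do not differ, so in this small series the change carries from one core to the other without a readable difference: the same change on two cores in this assay, a 1.0-fold lower number (0.02 log units; within the scatter) from compound 1 to compound 2 and a 1.2-fold higher number (0.06 log units; within the scatter) from compound 3 to compound 4, 1.2-fold (0.08 log units) apart, within the scatter of two such steps. Within the data shown here, this agreement rests on only two cores and one place on the ring, and since neither step stands out from the scatter, it shows only that fluoro does little on these two cores, not that a change with a real effect would carry across them in the same way or that fluoro would behave alike on any further core.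

The compounds shown leave open whether a chloro group, a methoxy group or an amine in that same place on the phenyl would move the number on either core, and whether such a step would match across the two. They also leave open how a longer chain in the link to the oxime, or a carboxylic acid in place of the oxime, would read in this assay.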